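The source may report more compounds than this note shows. Statements on the series, on what has been measured and on what is new or still open speak of the compounds shown alone.

Three amides built on one shared core have been run through a functional assay on MCF7 cells (Homo sapiens) for antiproliferative activity, read by MTT assay, with a stated time of 48 h; on this read-out lower numbers stand for stronger inhibition and higher numbers for weaker inhibition. Compound 1 `COc1cc(CNC(=O)CCCCCCC(C)C)ccc1OCCCCOc1ccc(-c2cc(=S)ss2)cc1` gives 49500 nM. Compound 2 `COc1cc(CNC(=O)CCCCCCC(C)C)ccc1OCCCCCOc1ccc(C(N)=S)cc1` gives 49300 nM in this assay. Compound 3 `COc1cc(CNC(=O)CCCC/C=C/C(C)C)ccc1OCCCCOc1ccc(C(N)=S)cc1` gives 49800 nM in this assay. The three numbers sit practically on top of one another: the gap from compound 3 to compound 1 and the gap from compound 3 to compound 2 both fall within the scatter of repeated measurements, so nothing separates compound 3 from its two neighbours and no order among the three can be read.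

Compound 4 `COc1cc(CNC(=O)CCCCCCC(C)C)ccc1OCCCCOc1ccc(C(N)=S)cc1` differs from compound 3 in a single place: isopentyl in place of 3-methylbut-1-en-1-yl on a saturated chain carbon, four bonds along the chain from a carbonyl carbon. Both groups count five carbon atoms and neither carries a donor or acceptor; the leaving group alone carries a double bond outside aromatic rings. Among the compounds with values here, no measured pair isolates this change, and what the measured compounds show is only that three structurally distinct members all return the same number within scatter.

On that basis the step from compound 3 to compound 4 is expected to stay within the scatter, with a 1.0-fold lower number from compound 3 to compound 4 (0.01 log units; within the scatter) in this assay. Compound 4 is therefore estimated at 49000 nM in this assay, within a range of 25000 nM to 95000 nM.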

Compound 4, half-maximal inhibitory concentration: 4990 nM
Compound 4: middle estimate off by 9.8-fold (0.99 log units), on the high side, outside the stated range (below it).
By their numbers in this assay, from the lowest: compound 4; then compounds 2, 1 and 3 (each within the scatter of the next).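

Isopentyl in place of 3-methylbut-1-en-1-yl, on a saturated chain carbon, four bonds along the chain from a carbonyl carbon, gives a 10-fold lower number from compound 3 to compound 4 (1.00 log units; beyond the scatter) in this assay, so at this position the double bond that only the leaving group carries goes with a step beyond the scatter, even though both groups count the same heavy atoms. Two other single-place steps end at the same compound: the change on a saturated chain carbon, four bonds along the chain from an oxygen on an aromatic ring, gives a 9.9-fold lower number from compound 2 to compound 4 (0.99 log units; beyond the scatter), and the group without a ring in place of the group with a five-membered aromatic ring, on an aromatic carbon, gives a 9.9-fold lower number from compound 1 to compound 4 (1.00 log units; beyond the scatter). The agreement among the first three compounds therefore did not mean that the series is insensitive to structure: each of these three changes, taken alone, moves the number beyond the scatter.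

Nothing at hand accounts for these steps. Still open, going by these compounds, is how a longer chain, a cyclohexyl group or a carboxylic acid in place of isopentyl would read on this position, and whether the saturated chain keeps its advantage with other groups elsewhere on the core.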